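The source may report more compounds than this note shows. Statements on the series, on what has been measured and on what is new or still open speak of the compounds shown alone.

In a functional assay on Caco-2 cells (Homo sapiens) for inhibition, read by MTT assay, with a stated time of 48 h, tested at 10 uM (on this read-out higher numbers stand for more inhibition of growth at the one concentration tested and lower numbers for less inhibition of growth), compound 1 (`Cc1cc(=O)c2c(O)cc(OCc3ccc([N+](=O)[O-])cc3)c([C@H]3CCN(C)C[C@H]3O)c2o1`) gives 14%, compound 2 (`Cc1cc(=O)c2c(O)c(CN3CC(O)CC3C(=O)O)c(O)c([C@H]3CCN(C)C[C@H]3O)c2o1`) gives 19% and compound 3 (`Cc1oc2c([C@H]3CCN(C)C[C@H]3O)c(O)cc(O)c2c(=O)c1C(O)c1cccc(Cl)c1`) gives 4%. Compound 3 therefore lies within the scatter of compound 1 and beyond the scatter under compound 2. Compound 4 (`Cc1oc2c([C@H]3CCN(C)C[C@H]3O)c(O)cc(O)c2c(=O)c1C(O)c1c(F)cccc1Cl`) carries 2-chloro-6-fluorophenyl in place of 3-chlorophenyl on a saturated chain carbon bound to an aromatic carbon and an oxygen on a saturated carbon. Among the compounds with values here, no measured pair differs in one place, so the series gives no direct guide to this change, and no step beyond the scatter is expected. The estimated step, a number 4 percentage points higher from compound 3 to compound 4 (within the scatter), is expected to stay within the scatter. For compound 4 the expected value is 8%, with an estimated range from 0% to 20%.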

Compound 4, percent growth inhibition at one concentration: 18%
The estimate for compound 4 lay 10 percentage points below the measured number; the measured number falls inside the stated range.
By their numbers in this assay, from the lowest: compounds 3, 1, 4 and 2 (each within the scatter of the next, the first and the last beyond it).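

In this assay, within the data shown here, the saturated chain carbon bound to an aromatic carbon and an oxygen on a saturated carbon gives the first step between compounds that differ in one place: 2-chloro-6-fluorophenyl in place of 3-chlorophenyl gives a number 14 percentage points higher from compound 3 to compound 4 (beyond the scatter), a modest step. Growth inhibition at the one concentration tested therefore responds to a change in the aryl group at this position. Nothing measured here accounts for the step.

From the compounds shown here alone, whether 2-chlorophenyl or 2-fluorophenyl alone would carry this step stays open. So does the effect of a methoxy group or an amine on the aryl ring.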